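The compounds below may be only part of what the source reports. "The series", "measured", "known", "first", "only" and "open" are said of these compounds alone.

Values in a functional assay on A549 cells (Homo sapiens) for inhibition, read by MTT assay, with a stated time of 72 h; a higher number here means a weaker inhibitor, a lower number a stronger inhibitor:
- compound 1 `Cc1ccc(-c2nnc(SCCCN3CCN(c4nc5ccccc5o4)CC3)o2)cc1`: 106000 nM
- compound 2 `Fc1ccc(-c2nnc(SCCCN3CCN(c4nc5ccccc5o4)CC3)o2)cc1`: 75700 nM
- compound 3 `Brc1ccc(-c2nnc(SCCCN3CCN(c4nc5ccccc5o4)CC3)o2)cc1`: 123000 nM

Compound 3, at 123000 nM, lies within the scatter of both other compounds: a 1.2-fold higher number from compound 1 to compound 3 (0.06 log units; within the scatter) and a 1.6-fold higher number from compound 2 to compound 3 (0.21 log units; within the scatter). The next change gives compound 4 `CC(C)(C)Oc1ccc(-c2nnc(SCCCN3CCN(c4nc5ccccc5o4)CC3)o2)cc1`, with tert-butoxy in place of bromo on an aromatic carbon. The measured swaps on this aromatic carbon bear on it, and a 1.4-fold lower number from compound 1 to compound 2 (0.15 log units; within the scatter) also stays within the scatter. Among the measured compounds shown here, no measured compound carries tert-butoxy, so the range is kept wide. No step beyond the scatter is expected, and the expected step is a 1.2-fold lower number from compound 3 to compound 4 (0.09 log units; within the scatter). Compound 4 is estimated at 100000 nM, with an expected range of 50000 nM to 200000 nM.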

Compound 4, half-maximal inhibitory concentration: 263000 nM
Compound 4: the middle estimate sits 2.6-fold (0.42 log units) below what was measured; measured number above the stated range.
By their numbers in this assay, from the lowest: compounds 2, 1 and 3 (each within the scatter of the next); then compound 4.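

In this assay, among the compounds shown here, tert-butoxy is the first group at this aromatic carbon to give a step beyond the scatter, and all three steps run towards a weaker inhibitor (a 2.1-fold higher number from compound 3 to compound 4 (0.33 log units; beyond the scatter); a 3.5-fold higher number from compound 2 to compound 4 (0.54 log units; beyond the scatter); a 2.5-fold higher number from compound 1 to compound 4 (0.39 log units; beyond the scatter)). Methyl, fluoro and bromo stayed within the scatter of one another, so this position does respond to at least one substituent. No supporting measurement accounts for the shift.

On these data alone, whether methoxy, an amine or a carboxylic acid here would give a stronger inhibitor remains open. So does whether the shift reflects the oxygen or the tert-butyl part of the group.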